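The source may hold more compounds than are shown below. What is called first, only, known or untested is meant among the compounds shown, and "the series" means these compounds.

Compound 1 `COc1nn(Cc2ccccc2[N+](=O)[O-])c(=O)o1` gives 36% in an assay on COS-7 cells for inhibition of Fatty-acid amide hydrolase 1 (Homo sapiens), read by scintillation counting, with a stated time of 10 min, tested at 10 uM; a lower number here means less inhibition, a higher number more inhibition at the concentration tested (going by the name of the read-out). Compound 3 `COc1nn(Cc2ccccc2NC(C)=O)c(=O)o1` differs from it in one place acetamido in place of nitro on an aromatic carbon and in this assay compound 3 gives 11%, so this change made the step of a number 25 percentage points lower from compound 1 to compound 3 (beyond the scatter). Compound 2 `COc1nn(Cc2cccc([N+](=O)[O-])c2)c(=O)o1` is built from the same atoms as compound 1, joined differently; how the two cores differ is not broken down here. In this assay compound 2 gives 7%, a number within the scatter of that of compound 3. Compound 4 `COc1nn(Cc2cccc(NC(C)=O)c2)c(=O)o1` has not yet been measured. It differs from compound 2 by acetamido in place of nitro on an aromatic carbon. This is the same kind of change as that from compound 1 to compound 3, but the place differs: in compound 4 the entering group sits meta to a group of 9 heavy atoms, in compound 3 ortho to a group of 9 heavy atoms. Compound 4 is expected to show a step of a number 3 percentage points lower from compound 2 to compound 4 (within the scatter), smaller than the earlier one. That expectation rests on compound 2 already giving 7%, which leaves little room for a drop of the earlier size. Compound 4 is estimated at 4%, between -8% and 14%.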

Compound 4, a percentage reported as inhibition, at one concentration (the size of the read-out at that concentration, not a potency): "not active" (no number reported)
Compound 4 has no reported number here; the estimate stays without a comparison.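

Among these compounds, compound 4 is reported as not active in this assay, without a number, so no step from compound 2 to compound 4 can be read. The compounds shown leave open whether swapping nitro for acetamido has the same size of effect at both places on the ring, and no measured evidence bears on this result.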